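Adding a Benzyloxycarbonylmethyl Branch to an Oral Analgesic Scaffold

A few compounds are considered here, and "the series" means these few. Any claim that something is new, unique, unknown or untested is made for them only; others in the source may bear on it.

Measured so far:
- compound 1 `O=C(CN(c1nc(Cl)nc2[nH]cnc12)C1CC1)NCC(=O)OCc1ccccc1` gives 21.7%
- compound 2 `O=C(CN(c1ncnc2c1ncn2C1CCCCO1)C1CC1)NCC(=O)OCc1ccccc1` gives 17.2%

Both values come from a functional assay on the whole organism (Tail, strain ICR) with Mus musculus as the target, in the tail flick test, with a stated time of 120 min, at a dose of 25 umol/kg by the oral route; a higher number here means a stronger effect of the compound at the dose given, a lower number a weaker effect. Compound 1 has the higher of the two numbers, but compound 2 lies within the scatter of it, so the two cannot be told apart. Compound 3 `O=C(CN(c1nc(Cl)nc2[nH]cnc12)C1CC1)N[C@@H](CC(=O)OCc1ccccc1)C(=O)OCc1ccccc1` is not yet measured. It differs from compound 1 by (benzyloxycarbonyl)methyl in place of hydrogen on a saturated chain carbon bound to an amide-type nitrogen and a carbonyl carbon. No comparable change has been measured here, so no step beyond the scatter is expected; the step from compound 1 to compound 3 is estimated as a number 0.7 percentage points lower from compound 1 to compound 3 (within the scatter). Compound 3 is therefore expected to give about 21%, between 6% and 38%.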

Compound 3, a percentage reported as activity, at one dose (the size of the read-out at that dose, not a potency): 12.1%
Beside the measured number, compound 3's estimate is 8.9 percentage points above it; measured number inside the range.
By their numbers in this assay, from the lowest: compounds 3, 2 and 1 (each within the scatter of the next).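

In this assay, putting (benzyloxycarbonyl)methyl in place of hydrogen on the saturated chain carbon bound to an amide-type nitrogen and a carbonyl carbon gives a step of a number 9.6 percentage points lower from compound 1 to compound 3 (within the scatter). For the compounds shown here, this is the first change tested at this position, and even a branch of this size leaves the two compounds indistinguishable at this dose. Nothing measured here bears on the reason for this result. Open, as far as these compounds go, is whether a plain methyl or a free carboxylic acid at this carbon would give a step beyond the scatter.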